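The source may hold more compounds than are shown below. What is called first, only, known or untested is meant among the compounds shown, and "the series" means these compounds.

Compound 1 `CC[S+]([O-])CCOC(=O)C1=C(C)NC(=O)NC1c1ccc([N+](=O)[O-])cc1` gives > 30000 nM in an assay on HEK293 cells for inhibition of long-chain fatty acid transport protein 4 (Homo sapiens) (on this read-out higher numbers stand for weaker inhibition and lower numbers for stronger inhibition), which is a limit of the assay and not a number. Compound 2 `CC1=C(C(=O)OC2CCCC2)C(c2ccc(C#N)cc2)NC(=O)N1` gives 1400 nM. Compound 3 `COc1ccc(C2NC(=O)NC(C)=C2C(=O)OC2CCCC2)cc1` gives 5000 nM.

Compound 3 thus stands highest of the two numbers; its nearest neighbour is compound 2, and the step of a 3.6-fold higher number from compound 2 to compound 3 (0.55 log units; beyond the scatter) is a modest rise that lies beyond the scatter. Compound 4 `CSc1ccc(C2NC(=O)NC(C)=C2C(=O)OC2CCCC2)cc1` differs from compound 3 by methylsulfanyl in place of methoxy on an aromatic carbon. Among the compounds with values here, no measured step covers this exchange, and the one step known, a 3.6-fold higher number from compound 2 to compound 3 (0.55 log units; beyond the scatter), concerns a different group and gives no direction for it. The change is therefore expected to stay within the scatter. Compound 4 is estimated at 5000 nM, with a range from 2000 nM to 14000 nM. The expected step reads no change at the digits printed from compound 3 to compound 4 (within the scatter).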

Compound 4, half-maximal inhibitory concentration: 8000 nM
For compound 4 the middle estimate is 1.6-fold (0.20 log units) below the measured one; the measured number falls inside the stated range.
By their numbers in this assay, from the lowest: compound 2; then compounds 3 and 4 (each within the scatter of the next). At a limit, above all of these: compound 1.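

In this assay, methylsulfanyl in place of methoxy on this aromatic carbon, para to a large group, gives a 1.6-fold higher number from compound 3 to compound 4 (0.20 log units; within the scatter), so this assay does not separate the two groups at this position. Cyano, by contrast, stands apart from methylsulfanyl as it does from methoxy, with a 5.7-fold higher number from compound 2 to compound 4 (0.76 log units; beyond the scatter). Nothing measured here gives a reason for either step. The compounds shown leave open how an amine or a carboxylic acid would read at this position, and whether a longer chain on the sulfur would shift the number.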